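A Longer Unsaturated Chain on an Inactive Compound

The compounds below may be only part of what the source reports. "The series", "measured", "known", "first", "only" and "open" are said of these compounds alone.

In an ADME assay on CHO-K1 cells (Cricetulus griseus) for cytotoxicity, read by MTT assay, with a stated time of 24 h (a lower number here means a stronger inhibitor, a higher number a weaker inhibitor), compound 1 (`CCCCCCCCCCCC(=O)Nc1nnc(S[C@@H]2O[C@H](COC(C)=O)[C@H](OC(C)=O)[C@H](OC(C)=O)[C@H]2OC(C)=O)s1`) gives 27700 nM while compound 3 (`C=CCCCCCCCCC(=O)Nc1nnc(S[C@@H]2O[C@H](COC(C)=O)[C@H](OC(C)=O)[C@H](OC(C)=O)[C@H]2OC(C)=O)s1`) gives 16300 nM on the same scale. Compound 2 (`CCCCCCCCCCCCCCCCCC(=O)Nc1nnc(S[C@@H]2O[C@H](CO)[C@H](O)[C@H](O)[C@H]2O)s1`) has no single number and stands as "not active" (no number reported) there, so it offers no value to step from.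

Compound 4 (`CCCCCCCC/C=C\CCCCCCCCCCCC(=O)Nc1nnc(S[C@@H]2O[C@H](CO)[C@H](O)[C@H](O)[C@H]2O)s1`) keeps the shared core and free hydroxyl groups of compound 2. The change is dec-1-en-1-yl in place of hexyl on a saturated chain carbon, ten or more bonds along the chain from a carbonyl carbon.

Of the measured steps, only a 1.7-fold lower number from compound 1 to compound 3 (0.23 log units; within the scatter) concerns the chain. That step stays within the scatter, but it is a smaller change, vinyl in place of propyl, and both of its compounds carry acetyl groups that compound 2 and compound 4 lack. For the measured compounds named here, it therefore bears only loosely on this case, and no measured step starts from compound 2.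

No clear change from compound 2 is expected in this assay for compound 4, and a report without a number is the likeliest outcome. If a number does appear, compound 4 is estimated at 100000 nM (expected range 30000 nM to 300000 nM).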

Compound 4, half-maximal inhibitory concentration: "not active" (no number reported)
Nothing numeric was reported for compound 4; there is nothing to compare the estimate with.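

In this assay compound 2 and compound 4 both stand without a number, so no step can be read between them. Nothing measured here offers an explanation for this result. The compounds shown leave open whether dec-1-en-1-yl in place of hexyl changes the read-out at all where the free hydroxyl groups are kept.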